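A few compounds are considered here, and "the series" means these few. Any claim that something is new, unique, unknown or untested is made for them only; others in the source may bear on it.

Values in a functional assay on RT-112 cells (Homo sapiens) for antiproliferative activity, read by MTT assay, with a stated time of 72 h (a higher number here means a weaker inhibitor of growth, a lower number a stronger inhibitor of growth), so far:
- compound 1 `COc1cc(Nc2ncnc3c(NC(=O)Nc4cc(Cl)c(Cl)cc4Cl)cccc23)cc(OC)c1` gives 4890 nM in this series
- compound 2 `COc1cc(Nc2ncnc3c(NC(=O)Nc4ccc(Cl)cc4Cl)cccc23)cc(OC)c1` gives 3060 nM in this series

Compound 2 (3060 nM) stands level with compound 1 (4890 nM) on these two numbers. Within the data shown here, the only measured step is a 1.6-fold lower number from compound 1 to compound 2 (0.20 log units; within the scatter) for hydrogen in place of chloro on an aromatic carbon. Compound 3 `COc1cc(Nc2ncnc3c(NC(=O)c4cc(=O)c5ccccc5o4)cccc23)cc(OC)c1` differs from compound 2 by a group of 11 heavy atoms (9 carbon, 2 oxygen; one six-membered aromatic ring of carbon only, one six-membered aromatic ring with 1 hetero atom) in place of a group of 9 heavy atoms (6 carbon, 1 nitrogen, 2 chlorine; one six-membered aromatic ring of carbon only), on a carbonyl carbon and so loses the (2,4-dichlorophenyl)amino group. The measured step covers a far smaller change and gives no direction for this one, so no shift beyond the scatter is expected in this assay on present evidence. The expected change is a 1.1-fold higher number from compound 2 to compound 3 (0.06 log units; within the scatter) with wide uncertainty. For compound 3 the estimate is 3500 nM (expected range 1000 nM to 12000 nM).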

Compound 3, concentration for 50% growth inhibition: > 20000 nM
Compound 3 gave a limit, no number; the forecaster's own chance of this, stated with the estimate: 15%; at least 5.7-fold (0.75 log units) between middle value and limit.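

In this assay compound 3 gives > 20000 nM, which is a limit of the assay and not a number: the limit of > 20000 nM in this assay, at which 1 of the 3 values shown sits.

Among these compounds, the group on the carbonyl carbon is not indifferent to change: replacing it gives an at least 6.5-fold higher number from compound 2 to compound 3 (0.81 log units; beyond the scatter) and an at least 4.0-fold higher number from compound 1 to compound 3 (0.61 log units; beyond the scatter), whereas the one earlier step, a 1.6-fold lower number from compound 1 to compound 2 (0.20 log units; within the scatter), showed no shift. The change replaces the whole (2,4-dichlorophenyl)amino group, so the step belongs to that replacement as a whole and not to any single part of it.

The compounds shown leave open whether the amino nitrogen or the chlorine atoms of the departing group account for the step. A plain phenylamino group without chlorine, or a cyclohexylamino group, on the same carbonyl carbon would begin to separate these parts.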